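Swapping nitro for chloro on a weakly antiproliferative glycoside

The compounds below may be only part of what the source reports. "The series", "measured", "known", "first", "only" and "open" are said of these compounds alone.

Compound 2 `O=[N+]([O-])c1ccc(-c2nc(CO[C@@H]3O[C@H](CSc4ncn[nH]4)[C@H]4OC5(CCCC5)O[C@@H]34)no2)cc1`: 24000 nM
Compound 1 `Nc1nnc(SC[C@H]2O[C@@H](OCc3noc(-c4ccc(Cl)cc4)n3)[C@@H]3OC4(CCCC4)O[C@@H]32)s1`: 30000 nM

In a functional assay on HBL-100 cells (Homo sapiens) for antiproliferative activity, read by sulforhodamine B assay, with a stated time of 48 h (on this read-out lower numbers stand for stronger inhibition of growth and higher numbers for weaker inhibition of growth), compound 2 gives the lowest of the two numbers, yet compound 1 sits within the scatter of it, so neither can be called stronger. Compound 3 `Clc1ccc(-c2nc(CO[C@@H]3O[C@H](CSc4ncn[nH]4)[C@H]4OC5(CCCC5)O[C@@H]34)no2)cc1` differs from compound 2 by chloro in place of nitro on an aromatic carbon. For the measured compounds named here, no measured pair shows this exact change, so a step in this assay is expected to stay within the scatter, with no clear direction. Compound 3 is therefore estimated at 27000 nM, between 12000 nM and 60000 nM, the expected step being a 1.1-fold higher number from compound 2 to compound 3 (0.05 log units; within the scatter).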

Compound 3, concentration for 50% growth inhibition: 24000 nM
For compound 3 the middle estimate is 1.1-fold (0.05 log units) above the measured one; measured number inside the range.
By their numbers in this assay, from the lowest: compounds 2, 3 and 1 (each within the scatter of the next).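

In this assay the change from 4-nitrophenyl to 4-chlorophenyl gives no change at the digits printed from compound 2 to compound 3 (within the scatter) so for this pair, the two groups cannot be told apart at this position. Compound 3 also allows a comparison at the sulfur, where 1H-1,2,4-triazol-5-yl in place of 5-amino-1,3,4-thiadiazol-2-yl gives a 1.3-fold lower number from compound 1 to compound 3 (0.10 log units; within the scatter) so that change cannot be told apart either. On these data alone, whether an amine or a carboxylic acid on this aromatic carbon would give a step beyond the scatter remains open. No available evidence bears on why these numbers stay so close.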